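The source may hold more compounds than are shown below. What is called first, only, known or untested is meant among the compounds shown, and "the series" means these compounds.

Measured compounds in a functional assay on HOP-62 cells (Homo sapiens) for cytotoxicity, read by sulforhodamine B assay, with a stated time of 48 h; a higher number here means that more compound is tolerated, a lower number that less compound is tolerated:
compound 1, `ClCc1ccccc1Cn1cnc2c(Cl)nc(Cl)nc21`, gives 6450 nM
compound 2, `ClCc1cccc(Cn2cnc3c(Cl)nc(Cl)nc32)c1`, gives 8310 nM
compound 3, `Nc1nc(Cl)c2ncn(Cc3ccccc3CCl)c2n1`, gives > 100000 nM

In this assay compound 1 gives 6450 nM and compound 2 gives 8310 nM. These two values lie within the usual scatter of each other, so no difference between compound 1 and compound 2 can be read from them. In this assay compound 3 reaches only a limit of the assay, > 100000 nM, and not a number.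

Compound 1 and compound 3 share a core and differ in one place: amino in place of chloro on an aromatic carbon. This change gives an at least 15-fold higher number from compound 1 to compound 3 (1.19 log units; beyond the scatter). The step is known only as a lower bound because of the limit of > 100000 nM in this assay, at which 1 of the 3 values shown sits. Compound 1 and compound 2 are built from the same atoms joined differently; the difference between the two cores is not broken down here.

Compound 4, `Nc1nc(Cl)c2ncn(Cc3cccc(CCl)c3)c2n1`, has not yet been measured in this assay. It stands to compound 2 as compound 3 stands to compound 1, the change being (amino in place of chloro on an aromatic carbon), the same change in the same surroundings. Among the measured compounds shown here, the step from compound 2 to compound 4 is expected to be an 18-fold higher number from compound 2 to compound 4 (1.26 log units; beyond the scatter), resting on the one measured example, compound 1 to compound 3, where the step was an at least 15-fold higher number from compound 1 to compound 3 (1.19 log units; beyond the scatter). Compound 4 is therefore expected to give about 150000 nM in this assay, most likely reported again only as a limit. Its value is estimated to fall between 60000 nM and 400000 nM.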

Compound 4, concentration lethal to 50% of the cells: 58900 nM
Estimate against measurement, compound 4: 2.5-fold (0.41 log units) above, outside the stated range (below it).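

In this assay, putting amino in place of chloro on an aromatic carbon moves the number the same way on the core of compound 2 as on the core of compound 1, giving a 7.1-fold higher number from compound 2 to compound 4 (0.85 log units; beyond the scatter), so more compound is tolerated after the change on both cores. Compound 3 reaches only a limit of the assay, > 100000 nM, and so the earlier step has a lower bound but no exact size. The two examples therefore show that the direction of the change carries from one core to the other, but they do not show that its size carries with it, and two cores are too few to support a rule for the wider series: the same change on two cores in this assay, an at least 15-fold higher number (1.19 log units; beyond the scatter) from compound 1 to compound 3 and a 7.1-fold higher number (0.85 log units; beyond the scatter) from compound 2 to compound 4; the limit leaves it open whether they differ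

As far as these compounds go, it remains open whether another group in the same place, such as methoxy or dimethylamino, would move the number in the same way as amino does. Also open, from the compounds shown here alone, is what would happen if the chloro group that remains on this ring in compound 3 and compound 4 were itself exchanged for an amine.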